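Replacing a bromobenzyl arm with a chlorophenyl arm

This account rests on a few compounds, and the source may have more. Where it says the series, first, only, none or still open, it means among the compounds named here.

Compound 2 `CCCn1c(=O)[nH]c2nc(-c3ccc(S(=O)(=O)N4CCN(Cc5ccc(Br)cc5)CC4)cc3)[nH]c2c1=O` has the lowest number of the three measured compounds in an assay on CHO cells for displacement of a labelled ligand from adenosine receptor A2b (Homo sapiens), read by scintillation counting, with a stated time of 75 min, in the presence of a further agent that is not named here (a lower number here means a stronger inhibitor, a higher number a weaker inhibitor), giving 0.153 nM. Its nearest neighbour is compound 3 `CCCn1c(=O)c2[nH]c(-c3ccc(S(=O)(=O)N4CCN(c5ccc(Cl)cc5)CC4)cc3)nc2n(C)c1=O`, which in this assay gives 1.91 nM, and the furthest is compound 1 `CCCn1c(=O)c2[nH]c(-c3ccc(S(=O)(=O)N4CCN(c5ccc(Cl)cc5)CC4)cc3)nc2n(CC)c1=O`, which in this assay gives 4.31 nM. Compound 2 differs from these two in more than one place, so their gap to it cannot be assigned to a single change; only the values themselves are known.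

The new compound 4 `CCCn1c(=O)[nH]c2nc(-c3ccc(S(=O)(=O)N4CCN(c5ccccc5Cl)CC4)cc3)[nH]c2c1=O` keeps the core of compound 2 and alters the group on the piperazine ring: 2-chlorophenyl in place of 4-bromobenzyl on an amine nitrogen in a ring.

Within the data shown here, the one measured step, a 2.3-fold lower number from compound 1 to compound 3 (0.35 log units; beyond the scatter), concerns a hydrogen in place of a methyl on the core and says nothing about the group on the amine nitrogen in a ring. Among the measured compounds shown here, no measured step bears directly on the change from compound 2 to compound 4. For the measured compounds named here, the only guidance is that compound 1 and compound 3, which both carry a 4-chlorophenyl on that nitrogen, sit well above compound 2, which carries the benzyl arm. The expectation is therefore a weaker result, with the step expected to be a 7.8-fold higher number from compound 2 to compound 4 (0.89 log units; beyond the scatter). Compound 4 is estimated at 1.2 nM, within a range of 0.3 nM to 5 nM.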

Compound 4, inhibition constant: 0.403 nM
For compound 4 the middle estimate is 3.0-fold (0.47 log units) above the measured one; the measured number falls inside the stated range.
By their numbers in this assay, from the lowest: compound 2; then compound 4; then compound 3; then compound 1.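

In this assay, among these compounds, replacing 4-bromobenzyl with 2-chlorophenyl on the amine nitrogen in a ring gives a 2.6-fold higher number from compound 2 to compound 4 (0.42 log units; beyond the scatter), the first measured step at this position, and it shows that compound 4 remains a strong inhibitor at 0.403 nM despite a modest weakening. The group on this nitrogen can therefore change from a benzyl arm to a phenyl ring bound directly to the nitrogen without a large loss, although the linking carbon, the halogen and the halogen's place on the ring all change in this one step, so the step cannot be divided among them. Nothing measured here explains the size of this step.

A 2-chlorobenzyl or 4-bromophenyl arm on the same core would help separate these changes, and compounds 1 and 3 cannot do so, as each differs from compound 2 and compound 4 in more than one place. Going by these compounds, it also remains open whether this nitrogen would tolerate an arm with no aromatic ring, such as cyclohexyl, or one carrying a carboxylic acid.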